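The compounds below may be only part of what the source reports. "The series", "measured", "known", "first", "only" and "open" are said of these compounds alone.

Compound 1 `O=C(Nc1ccc(Cl)c(-c2nnc3c(Cl)cccn23)c1)c1ccc(F)cc1Cl`; compound 2 `O=C(Nc1ccc(Cl)c(-c2nnc3c(Cl)cccn23)c1)c1ccccn1`; compound 3 `O=C(Nc1ccc(Cl)c(-c2nnc3c(Cl)cccn23)c1)c1cccc(Cl)c1`.

In a functional assay on T47D cells (Homo sapiens) for antiproliferative activity, read by MTT assay, with a stated time of 72 h (a higher number here means a weaker inhibitor, a lower number a stronger inhibitor), compound 1 gives > 100000 nM, a limit of the assay. In this assay compound 2 gives > 100000 nM, likewise a limit. Among the measured compounds shown here, compound 3 gives 30200 nM, the only number in the set (the limit of > 100000 nM in this assay, at which 2 of the 3 values shown sit). The readable steps are an at least 3.3-fold lower number from compound 1 to compound 3 (0.51 log units; beyond the scatter) and an at least 3.3-fold lower number from compound 2 to compound 3 (0.51 log units; beyond the scatter); the step that the two limits leave unreadable from compound 1 to compound 2.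

Compound 4 `O=C(Nc1ccc(Cl)c(-c2nnc3c(Cl)cccn23)c1)c1ccon1` differs from compound 3 by 1,2-oxazol-3-yl in place of 3-chlorophenyl on a carbonyl carbon. The step from compound 2 to compound 3 bears most: there a small aromatic ring carrying nitrogen on the carbonyl carbon sat at the limit, and the 1,2-oxazol-3-yl is again such a ring. A weakening beyond the scatter is expected, with a fair chance of a limit only. Compound 4 is therefore estimated at 80000 nM, in the range 20000 nM to 300000 nM. That corresponds to an expected step of a 2.6-fold higher number from compound 3 to compound 4 (0.42 log units; beyond the scatter).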

Compound 4, half-maximal inhibitory concentration: > 100000 nM
Compound 4 ended at the assay's limit (the forecaster's own chance of this, stated with the estimate: 55%); middle value at least 1.2-fold (0.09 log units) from the limit.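

In this assay, 1,2-oxazol-3-yl in place of 3-chlorophenyl on the carbonyl carbon gives an at least 3.3-fold higher number from compound 3 to compound 4 (0.51 log units; beyond the scatter). Among the groups shown, 3-chlorophenyl alone still gives a number at this position, and the steps among compound 1, compound 2 and compound 4 cannot be read. A five-membered aromatic ring with 2 hetero atoms now joins the two earlier groups at the same limit: the limit of > 100000 nM in this assay, at which 3 of the 4 values shown sit.

On these data alone, whether the number of compound 3 rests on its chlorine or on its carbon-only ring stays open. An unsubstituted phenyl or a methoxyphenyl on this carbonyl carbon would help separate the two.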